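The compounds below may be only part of what the source reports. "The series", "measured", "known", "first", "only" and "open" are said of these compounds alone.

Of the compounds shown here, three sharing one core have been measured in an ADME assay on MDCK cells (Canis lupus familiaris) for permeability (on this read-out higher numbers stand for higher permeability and lower numbers for lower permeability), and give a first frame for the series. Compound 1 (`Cn1cc(-c2cc(C(N)=O)ccc2Oc2ccccc2)c2cc[nH]c2c1=O`) gives 14 10^-6 cm/s in this read-out, compound 2 (`CCS(=O)(=O)Nc1ccc(Oc2ccc(C#N)cc2)c(-c2cn(C)c(=O)c3[nH]ccc23)c1`) gives 11 10^-6 cm/s and compound 3 (`Cn1cc(-c2cc(NS(C)(=O)=O)ccc2Oc2cccnc2)c2cc[nH]c2c1=O`) gives 3 10^-6 cm/s there. Compound 2 thus stands within the scatter of compound 1, while compound 3 lies beyond the scatter below it.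

Compound 4 (`CCS(=O)(=O)Nc1ccc(OC2CCN(C)CC2)c(-c2cn(C)c(=O)c3[nH]ccc23)c1`) has no number yet. It differs from compound 2 in one place, on an oxygen on an aromatic ring, where 1-methylpiperidin-4-yl stands in place of 4-cyanophenyl (1-methylpiperidin-4-yl in place of 4-cyanophenyl on an oxygen on an aromatic ring). For the measured compounds named here, no two measured compounds differ in one place only, so the series offers no direct measure of such a step. The only hint is indirect and thin. Compound 1 and compound 2 both carry an aromatic ring of carbon only on that oxygen, whereas compound 3, at 3 10^-6 cm/s in this comparison, does not, and neither will compound 4.

A fall beyond the scatter is therefore expected, and the estimated size of it is a 2.8-fold lower number from compound 2 to compound 4 (0.44 log units; beyond the scatter) on this read-out. For compound 4 the expected value is 4 10^-6 cm/s (1.5 10^-6 cm/s to 10 10^-6 cm/s).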

Compound 4, apparent permeability: 0.55 10^-6 cm/s
Beside the measured number, compound 4's estimate is 7.3-fold (0.86 log units) above it, and the stated range ends above it.
By their numbers in this assay, from the lowest: compound 4; then compound 3; then compounds 2 and 1 (each within the scatter of the next).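

In this assay the series gains its first direct measure at this position: 1-methylpiperidin-4-yl in place of 4-cyanophenyl on an oxygen on an aromatic ring gives a 20-fold lower number from compound 2 to compound 4 (1.30 log units; beyond the scatter) in a step that counts as large. The number on this read-out thus depends strongly on the group held by that oxygen, even though the two groups are close in what is counted, with 7 heavy atoms against 8 and the same count of hydrogen-bond donors and acceptors; what differs is that a six-membered aromatic ring of carbon only and a triple bond give way to a six-membered non-aromatic ring with 1 hetero atom. Nothing available here accounts for the size of this fall, and its origin stays unassigned.

For the compounds shown here, the single pair does not separate the loss of the aromatic ring from the arrival of the ring nitrogen and its methyl, which cyclohexyl, unsubstituted phenyl or an unmethylated piperidin-4-yl on the same oxygen could tell apart. It also leaves open whether a step of this size would recur on a compound carrying a primary carboxamide instead of the ethylsulfonylamino group.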